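A few compounds are considered here, and "the series" means these few. Any claim that something is new, unique, unknown or untested is made for them only; others in the source may bear on it.

Compound 1 `C#CCNC(=O)/C(C)=C(\C)c1ccc(Cl)cc1`: 200 mg/kg
Compound 2 `C/C(C(=O)NC1CC1)=C(\C)c1ccc(Cl)cc1`: 600 mg/kg

In a toxicity assay on the whole organism (strain Icem-CET (SPF Caw)) for cytotoxicity, with Mus musculus as the target (a lower number here means that less compound is needed, a higher number that more compound is needed for the effect), compound 1 gives 200 mg/kg and compound 2 gives 600 mg/kg. Compound 2 thus holds the higher of the two numbers, and the gap between them lies beyond the usual scatter. Compound 3 `C/C(C(=O)NC1CC1)=C(/C)c1ccc(Cl)cc1` has not yet been measured. Compared with compound 2, (the two compounds have the same atoms and bonds and differ only in configuration as drawn: 1 of 1 stereo elements differ; a double bond is drawn Z in compound 2 and E in compound 3). For the measured compounds named here, no measured pair shows what such a change of drawn geometry does, so no direction can be read from the data, and a step either way beyond the scatter is possible. The expected value for compound 3 in this assay is 450 mg/kg, with a range from 150 mg/kg to 1200 mg/kg, which means an estimated step of a 1.3-fold lower number from compound 2 to compound 3 (0.12 log units; within the scatter).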

Compound 3, dose for half-maximal effect: 150 mg/kg
The estimate for compound 3 lay 3.0-fold (0.48 log units) above the measured number, within the range that was stated.
By their numbers in this assay, from the lowest: compounds 3 and 1 (each within the scatter of the next); then compound 2.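

In this assay, for the compounds shown here, the drawn geometry of the double bond proves to matter, which the earlier compounds could not show, with a 4.0-fold lower number from compound 2 to compound 3 (0.60 log units; beyond the scatter). This step can be tied to the double bond alone because of one fact: the fact that compounds 2 and 3 differ only in the configuration as drawn. Swapping propargyl for cyclopropyl on the amide nitrogen, by contrast, gives a 1.3-fold lower number from compound 1 to compound 3 (0.12 log units; within the scatter), so that exchange shows no clear effect. Still open, from the compounds shown here alone, is whether the geometry has the same effect with propargyl on that nitrogen. Also open, going by these compounds, is how a longer chain there would behave.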